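A methyl step from compound 3 to compound 4

The compounds below may be only part of what the source reports. "The series", "measured", "known", "first", "only" and "open" are said of these compounds alone.

Compound 1 `C[C@]1(O)C[C@](c2ccc(OC(F)(F)F)cc2)([C@H](O)c2ccccn2)C1` gives 100 mL/min/kg 
Compound 2 `C[C@]1(O)C[C@@](c2ccc(C(F)(F)F)cc2)([C@H](O)c2ccccn2)C1` gives 150 mL/min/kg 
Compound 3 `O[C@H](c1ccccn1)[C@]1(c2ccc(C(F)(F)F)cc2)C[C@H](O)C1` gives 50 mL/min/kg 

All three values come from an ADME assay on liver for metabolic stability, with Liver microsome (Rattus norvegicus) as the target, read by LC-MS, using microsomes, with a stated time of 5 h (a lower number here means slower removal, a higher number faster removal of the compound), and no two of these compounds differ in one place only. In this assay compound 3 lies within the scatter of compound 1 and beyond the scatter beneath compound 2. Compound 4 `C[C@]1(O)C[C@](c2ccc(C(F)(F)F)cc2)([C@H](O)c2ccccn2)C1` differs from compound 3 by methyl in place of hydrogen on a saturated ring carbon of the shared core. A methyl also sits on that ring carbon in compound 1, which reads 100 mL/min/kg here, and in compound 2, which reads 150 mL/min/kg here. A rise of modest size is therefore expected, estimated as a 2.4-fold higher number from compound 3 to compound 4 (0.38 log units; beyond the scatter) on these few numbers. Compound 4 is estimated at 120 mL/min/kg in this assay with an expected range from 60 mL/min/kg to 230 mL/min/kg across repeated measurements.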

Compound 4, clearance: 100 mL/min/kg
Estimate against measurement, compound 4: 1.2-fold (0.08 log units) above; the range from low to high includes it.
By their numbers in this assay, from the lowest: compounds 3, 1, 4 and 2 (each within the scatter of the next, the first and the last beyond it).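

In this assay, methyl in place of hydrogen on a saturated ring carbon of the four-membered ring gives a 2.0-fold higher number from compound 3 to compound 4 (0.30 log units; within the scatter), the first step read at this position. Trifluoromethyl in place of trifluoromethoxy on an aromatic carbon gives no change at the digits printed from compound 1 to compound 4 (within the scatter). The remaining step, a 1.5-fold lower number from compound 2 to compound 4 (0.18 log units; within the scatter), isolates stereochemistry from any change of atoms: the fact that compounds 2 and 4 differ only in the configuration as drawn

Only hydrogen and methyl are shown on this ring carbon, so the effect of an ethyl group or an amine there remains open.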